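The compounds below may be only part of what the source reports. "The series", "measured", "known", "first", "only" and "open" are said of these compounds alone.

Measured so far in an ADME assay on Vero cells (Chlorocebus sabaeus) for cytotoxicity; on this read-out lower numbers stand for higher toxicity in this test and higher numbers for lower toxicity in this test:
compound 1 `CCC(CC)NC(=O)c1cccc2[nH]c(-c3ccc(OC)c(OC)c3)nc12` gives 2.23 uM
compound 2 `COc1ccc(-c2nc3c(C(=O)Nc4cnc(Cl)cn4)cccc3[nH]2)c(OC)c1OC` gives 65.2 uM
compound 3 `COc1ccc(-c2nc3c(C(=O)Nc4c[nH]cn4)cccc3[nH]2)cc1OC` gives 306 uM

Compound 3 stands highest of the three numbers in this assay; its nearest neighbour is compound 2 with a lower number, and compound 1 lies furthest below. Among the measured compounds shown here, the one step that can be read in a single place is a 140-fold higher number from compound 1 to compound 3 (2.14 log units; beyond the scatter), a large rise, where 1H-imidazol-4-yl replaces pentan-3-yl on the amide-type nitrogen.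

Compound 4 `COc1ccc(-c2nc3c(C(=O)Nc4cnccn4)cccc3[nH]2)cc1OC` is not yet measured. It differs from compound 3 by pyrazin-2-yl in place of 1H-imidazol-4-yl on an amide-type nitrogen. For the measured compounds named here, no measured step matches this exchange of one small ring for another on the amide-type nitrogen; the large step from compound 1 to compound 3 concerns a chain-to-ring exchange and does not bear on it directly. Compound 2 carries a related pyrazinyl group but also a different methoxy pattern, so of compound 2 and compound 3 only the two values are shown, and they hint that the pyrazinyl series may sit somewhat lower than compound 3.

For compound 4 in this assay a modest step down is therefore expected, a 2.0-fold lower number from compound 3 to compound 4 (0.31 log units; beyond the scatter), though a value within the scatter of compound 3 would not surprise. The estimate for compound 4 is 150 uM, with a range of 40 uM to 500 uM.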

Compound 4, half-maximal toxic concentration: 98.8 uM
Compound 4: middle estimate off by 1.5-fold (0.18 log units), on the high side; measured number inside the range.
By their numbers in this assay, from the lowest: compound 1; then compounds 2 and 4 (each within the scatter of the next); then compound 3.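

In this assay, swapping one small aromatic ring for another on the amide-type nitrogen still moves the read-out: pyrazin-2-yl in place of 1H-imidazol-4-yl gives a 3.1-fold lower number from compound 3 to compound 4 (0.49 log units; beyond the scatter) and so this position responds to ring identity as well as to the chain-to-ring exchange. Measured against pentan-3-yl, pyrazin-2-yl gives a 44-fold higher number from compound 1 to compound 4 (1.65 log units; beyond the scatter) and thus the large rise on leaving the branched chain is not confined to 1H-imidazol-4-yl, with both rings in this three-compound set standing well above the chain and none going against that pattern. The ring exchange also alters ring size and hydrogen-bond donors together, and nothing available separates these changes or accounts for either step.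

As far as these compounds go, whether the higher numbers require ring nitrogen atoms remains open, since a phenyl or cyclohexyl group on the amide-type nitrogen would be needed to separate the presence of a ring from its hetero atoms. The separate contributions of the chloro substituent and the methoxy pattern in compound 2 cannot be read, as that compound differs from the others in more than one place.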